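Notes on the step from compound 2 to compound 3

The compounds below may be only part of what the source reports. "The series", "measured", "known", "first", "only" and "open" are said of these compounds alone.

In a physicochemical assay for lipophilicity (on this read-out higher numbers stand for higher lipophilicity and lower numbers for lower lipophilicity), compound 1 `CC(C)c1cc(I)cc(C(C)C)c1O` gives 5.75 and compound 2 `CC(C)c1cc(N)cc(C(C)C)c1O` gives 3.1, the lower of the two numbers. Compound 3 `CC(C)c1cc(NC(=O)C(F)(F)F)cc(C(C)C)c1O`, not yet measured, differs from compound 2 by (trifluoromethyl)carbonyl in place of hydrogen on a nitrogen on an aromatic ring, with (trifluoromethyl)carbonyl in place of hydrogen on a nitrogen on an aromatic ring. Within the data shown here, the only measured step is a number 2.65 log units lower from compound 1 to compound 2 (beyond the scatter), a large one, with amino in place of iodo on an aromatic carbon. Among the measured compounds shown here, it bears only indirectly, and no measured step changes the nitrogen itself. Expected in this assay is a number 1.40 log units higher from compound 2 to compound 3 (beyond the scatter), smaller in size than that measured step. For compound 3 the estimated value is 4.5, with an expected range of 3.9 to 5.1.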

Compound 3, partition coefficient: 4.46
For compound 3 the middle estimate is 0.04 log units above the measured one; measured number inside the range.
By their numbers in this assay, from the lowest: compound 2; then compound 3; then compound 1.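

In this assay the nitrogen itself now carries a measured change: (trifluoromethyl)carbonyl in place of hydrogen on a nitrogen on an aromatic ring gives a number 1.36 log units higher from compound 2 to compound 3 (beyond the scatter) and is a large step. The read-out at this position therefore responds to substitution on the amino nitrogen, not only to exchanging the group on the aromatic carbon. Nothing at hand accounts for the size of this step.

Still open, as far as these compounds go, is whether an acetyl group on the same nitrogen, carrying no fluorine, gives a step of similar size. Also open, from the compounds shown here alone, is how a methyl group or a longer fluorinated chain on that nitrogen would read.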